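This account rests on a few compounds, and the source may have more. Where it says the series, first, only, none or still open, it means among the compounds named here.

Compound 1 `CC1CCN(C(=S)SCc2ccc(C(=O)Nc3ccccc3N)cc2)CC1` gives 87.4% in a functional assay on A-375 cells (Homo sapiens) for antiproliferative activity, read by CCK-8 assay, with a stated time of 72 h, tested at 8 uM; on this read-out lower numbers stand for a weaker effect and higher numbers for a stronger effect at the one concentration tested; compound 2 `Nc1ccccc1NC(=O)c1ccc(CSC(=S)N2CCN(Cc3ccncc3)CC2)cc1` gives 89.5%.

Compound 2 carries the higher of these two numbers, but its gap to compound 1 lies within the usual scatter, so the two stand level. Compound 3 `Nc1ccccc1NC(=O)c1ccc(CSC(=S)N2CCN(Cc3ccccc3)CC2)cc1` differs from compound 2 in one place: phenyl in place of pyridin-4-yl on a saturated chain carbon bound to an amine nitrogen in a ring. Among the compounds with values here, no measured pair shows this change, so its effect is unknown. The step expected from compound 2 to compound 3 is small, in no firm direction, and not beyond the scatter: a number 3.5 percentage points lower from compound 2 to compound 3 (within the scatter). Compound 3 is therefore estimated in this assay at 86%, with a range from 72% to 95%.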

Compound 3, a percentage reported as inhibition, at one concentration (the size of the read-out at that concentration, not a potency): 29.3%
The estimate for compound 3 lay 56.7 percentage points above the measured number, outside the stated range (below it).
By their numbers in this assay, from the lowest: compound 3; then compounds 1 and 2 (each within the scatter of the next).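

In this assay this position proves far from indifferent: phenyl in place of pyridin-4-yl on a saturated chain carbon bound to an amine nitrogen in a ring brings a number 60.2 percentage points lower from compound 2 to compound 3 (beyond the scatter). The two groups have the same heavy-atom count, and the change swaps one ring nitrogen for carbon and removes the one counted hydrogen-bond acceptor. Nothing measured here explains the size of this step. The compounds shown leave open whether pyridin-3-yl or pyrimidin-5-yl would match compound 2. They also leave open whether an amine on the phenyl ring of compound 3 would change its number.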